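This account rests on a few compounds, and the source may have more. Where it says the series, first, only, none or still open, it means among the compounds named here.

Measured so far in an assay on isolated protein for inhibition of serine/threonine-protein kinase TNNI3K (Homo sapiens); on this read-out lower numbers stand for stronger inhibition and higher numbers for weaker inhibition:
compound 1 `O=C(Nc1ccc(Oc2cc(O)ncn2)cc1)Nc1cccc(C(F)(F)F)c1` gives 3200 nM
compound 2 `CNc1cc(Oc2c(C)cc(NC(=O)Nc3cccc(C(F)(F)F)c3)cc2C)ncn1` gives 25 nM
compound 3 `CNc1nccc(Oc2ccc(NC(=O)Nc3cccc(C(F)(F)F)c3)cc2)n1` gives 50 nM

Compound 3 holds the second highest of these three numbers; compound 2 lies closest to it, within the scatter, while compound 1 sits far above it, beyond the scatter. Compound 4 `O=C(Nc1ccc(Oc2cc(NCCO)ncn2)cc1)Nc1cccc(C(F)(F)F)c1` has not been measured. It differs from compound 3 in one place: 6-((2-hydroxyethyl)amino)pyrimidin-4-yl in place of 2-(methylamino)pyrimidin-4-yl on an oxygen on an aromatic ring. Among the compounds with values here, one measured step bears on this position, a 64-fold lower number from compound 1 to compound 3 (1.81 log units; beyond the scatter), which shows that the choice of group on this pyrimidine matters a great deal. Compound 2, carrying an amino substituent on the same side of the pyrimidine as compound 4, and compound 3 give numbers within the scatter of each other. The step of a 2.0-fold higher number from compound 3 to compound 4 (0.30 log units; within the scatter) is therefore expected to be small, at most a modest rise. Compound 4 is estimated at 100 nM, within 25 nM to 400 nM.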

Compound 4, half-maximal inhibitory concentration: 32 nM
Estimate against measurement, compound 4: 3.1-fold (0.49 log units) above; low and high end bracket the measured number.
By their numbers in this assay, from the lowest: compounds 2, 4 and 3 (each within the scatter of the next); then compound 1.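

In this assay, 6-((2-hydroxyethyl)amino)pyrimidin-4-yl in place of 2-(methylamino)pyrimidin-4-yl gives a 1.6-fold lower number from compound 3 to compound 4 (0.19 log units; within the scatter), so the larger group with its added oxygen is accepted at this position without a change beyond the scatter. On the same core, (2-hydroxyethyl)amino in place of hydroxy gives a 100-fold lower number from compound 1 to compound 4 (2.00 log units; beyond the scatter), which isolates a large step for this single exchange on an aromatic carbon. Nothing available gives a reason for either step. As far as these compounds go, whether a 2-methoxyethylamino group, or a chain ending in a carboxylic acid or a dimethylamine, would keep the number at this level remains open.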